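Methyl on the shared core: expected clearance of compound 4

The compounds below may be only part of what the source reports. "The series", "measured", "known", "first", "only" and "open" are said of these compounds alone.

In an ADME assay on microsomes from liver (Homo sapiens) for metabolic stability (on this read-out higher numbers stand for fast clearance and lower numbers for slow clearance), compound 2 `CNC(=O)c1sc(N2CC3CC2(CNC(=O)c2c[nH]c4ncccc24)C3)nc1C(F)(F)F` reads 200 mL.min-1.g-1 and stands within the scatter of compound 1 `CNC(=O)c1sc(N2CC3CC2(CNC(=O)c2c[nH]c4ncc(C(F)(F)F)cc24)C3)nc1C(F)(F)F` at 130 mL.min-1.g-1 on the same core.

Compound 3 `CNc1nc(OCC2CCC2)nc2c1ncn2Cc1c(F)cccc1F` gives > 270 mL.min-1.g-1 as a limit of the assay and not a number.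

Compound 4 `CNC(=O)c1sc(N2CC3CC2(CNC(=O)c2c[nH]c4ncc(C)cc24)C3)nc1C(F)(F)F` differs from compound 2 by methyl in place of hydrogen on an aromatic carbon of the six-membered aromatic ring with 1 nitrogen.

For the measured compounds named here, the one measured step at that carbon is a 1.5-fold higher number from compound 1 to compound 2 (0.19 log units; within the scatter) for hydrogen in place of trifluoromethyl, and it lies within the scatter.

Given that step, the estimated 1.1-fold lower number from compound 2 to compound 4 (0.02 log units; within the scatter) stays within the scatter in this assay with no firm direction.

Compound 4 is expected at 190 mL.min-1.g-1 with an estimated range of 110 mL.min-1.g-1 to 270 mL.min-1.g-1 for the read-out.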

Compound 4, intrinsic clearance in microsomes in the Homo sapiens assay: > 270 mL.min-1.g-1
Compound 4 gave a limit, no number; the forecaster's own chance of this, stated with the estimate: 15%; middle value at least 1.4-fold (0.15 log units) away from the limit.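

In the Homo sapiens assay compound 4 gives > 270 mL.min-1.g-1, a limit of the assay and not a number. Methyl in place of hydrogen on this aromatic carbon gives an at least 1.3-fold higher number from compound 2 to compound 4 (0.13 log units; that floor lies within the scatter), so only a floor is known. For the compounds shown here, in the Homo sapiens assay, methyl in place of trifluoromethyl gives an at least 2.0-fold higher number from compound 1 to compound 4 (0.31 log units; beyond the scatter), the first step at this carbon to pass the scatter.

In a physicochemical assay for solubility (on this read-out lower numbers stand for lower solubility and higher numbers for higher solubility), compound 2 gives < 1600 nM, a limit of the assay and not a number. In the physicochemical assay compound 4 gives < 1600 nM, also a limit of the assay and not a number. On these data alone, the step in the physicochemical assay cannot be read, as compound 2 and compound 4 share one limit: the limit of < 1600 nM in the physicochemical assay, at which 2 of the 2 values shown sit. How an amine or a methoxy group on this carbon would read remains open.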